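Ethyl in place of 4-acetylphenyl: compound 3 to compound 4

The compounds below may be only part of what the source reports. "The series", "measured", "known", "first", "only" and "open" are said of these compounds alone.

Values in a functional assay on HUVEC cells (Homo sapiens) for inhibition; on this read-out lower numbers stand for stronger inhibition and higher numbers for weaker inhibition:
- compound 1 `CN(c1ccc(NC(=O)Nc2ccccc2)cc1)c1ccnc(Nc2cccc(CS(C)(=O)=O)c2)n1`: 0.2 nM
- compound 2 `CN(c1ccc(N/C(S)=N/c2ccccc2)cc1)c1ccnc(Nc2cccc(CS(C)(=O)=O)c2)n1`: 6 nM
- compound 3 `CC(=O)c1ccc(NC(=O)Nc2ccc(N(C)c3ccnc(Nc4cccc(CS(C)(=O)=O)c4)n3)cc2)cc1`: 2 nM

Compound 3 holds the middle of the three values in this assay. Its nearest neighbour is reached by a 3.0-fold lower number from compound 2 to compound 3 (0.48 log units; beyond the scatter), and its furthest by a 10-fold higher number from compound 1 to compound 3 (1.00 log units; beyond the scatter).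

The next compound is compound 4 `CCNC(=O)Nc1ccc(N(C)c2ccnc(Nc3cccc(CS(C)(=O)=O)c3)n2)cc1`. The change is ethyl in place of 4-acetylphenyl on an amide-type nitrogen, in words ethyl in place of 4-acetylphenyl on an amide-type nitrogen.

Among the measured compounds shown here, no measured compound carries anything other than an aromatic ring on that nitrogen, so the loss of the ring itself is untested. The closest evidence is a 10-fold higher number from compound 1 to compound 3 (1.00 log units; beyond the scatter), which shows that adding the acetyl raised the number. Taken alone, losing the acetyl would point towards a lower number. For the measured compounds named here, the other two steps, a 30-fold higher number from compound 1 to compound 2 (1.48 log units; beyond the scatter) and a 3.0-fold lower number from compound 2 to compound 3 (0.48 log units; beyond the scatter), show only that changes in this part of the molecule can shift the read-out, and neither involves an alkyl group. A modest rise is therefore expected, though the direction is uncertain. The estimated step is a 3.0-fold higher number from compound 3 to compound 4 (0.48 log units; beyond the scatter). For compound 4 the estimated value is 6 nM, with an expected range of 1 nM to 40 nM.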

Compound 4, half-maximal inhibitory concentration: 3 nM
The estimate for compound 4 lay 2.0-fold (0.30 log units) above the measured number; low and high end bracket the measured number.
By their numbers in this assay, from the lowest: compound 1; then compounds 3, 4 and 2 (each within the scatter of the next, the first and the last beyond it).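

In this assay, among the compounds shown here, the first group without a ring on the amide-type nitrogen gives a 1.5-fold higher number from compound 3 to compound 4 (0.18 log units; within the scatter) on replacing 4-acetylphenyl, so ethyl and 4-acetylphenyl cannot be told apart on this read-out, and the wider replacement on the nitrogen on the aromatic ring, a 2.0-fold lower number from compound 2 to compound 4 (0.30 log units; within the scatter), is likewise unresolved. Unsubstituted phenyl alone stands apart from ethyl: a 15-fold higher number from compound 1 to compound 4 (1.18 log units; beyond the scatter) shows that the aromatic ring on this nitrogen is not interchangeable with ethyl when the ring carries no acetyl, and the low number of compound 1 is therefore tied to phenyl itself, not simply to the presence of any group at this position. No measurement at hand accounts for these differences.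

From the compounds shown here alone, whether a longer chain such as butyl, a cyclohexyl ring or a benzyl group on the amide-type nitrogen would approach compound 1 or stay level with compound 4 remains open. Also open, going by these compounds, is whether a smaller substituent on the phenyl ring, such as fluorine or methoxy, would keep the low number of compound 1 or, like acetyl, move away from it.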